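This account rests on a few compounds, and the source may have more. Where it says the series, first, only, none or still open, it means among the compounds named here.

Compound 1 `CCOC(=O)C1CCCCN1S(=O)(=O)c1ccc(S(=O)(=O)N(CC)CC)cc1` gives 24600 nM in a functional assay on MIA PaCa-2 cells (Homo sapiens) for inhibition, read by MTT assay, with a stated time of 7 days; a higher number here means a weaker inhibitor, a lower number a stronger inhibitor.
Compound 2 `CCOC(=O)[C@@H]1CCCN(S(=O)(=O)c2ccc(S(=O)(=O)N3CCCCC3)cc2)C1` gives 2900 nM in this assay.
Compound 3 `CCOC(=O)[C@@H]1CCCN(S(=O)(=O)c2ccc(S(=O)(=O)N(C)C)cc2)C1` gives 900 nM in this assay.

Compound 3 stands at the lowest number of the three, with compound 2 nearest and compound 1 furthest. Compound 4 `CCCN(CC)S(=O)(=O)c1ccc(S(=O)(=O)N2CCC[C@@H](C(=O)OCC)C2)cc1` differs from compound 3 by ethyl(propyl)amino in place of dimethylamino on a sulfonyl sulfur. Within the data shown here, the one measured step at this sulfonyl sulfur, a 3.2-fold lower number from compound 2 to compound 3 (0.51 log units; beyond the scatter), went toward the smaller amine; compound 4 goes the other way, to a larger acyclic amine. Among the measured compounds shown here, compound 1 also carries an acyclic dialkylamino there, but its core differs from that of compound 3, and no single step links them. A modest rise in the number is therefore expected, a 2.2-fold higher number from compound 3 to compound 4 (0.35 log units; beyond the scatter). For compound 4 the estimate is 2000 nM, in the range 700 nM to 6000 nM.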

Compound 4, half-maximal inhibitory concentration: 300 nM
For compound 4 the middle estimate is 6.7-fold (0.82 log units) above the measured one, and the stated range ends above it.
By their numbers in this assay, from the lowest: compound 4; then compound 3; then compound 2; then compound 1.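

In this assay, going from dimethylamino to the larger ethyl(propyl)amino on the sulfonyl sulfur brings a further fall in the number (a 3.0-fold lower number from compound 3 to compound 4 (0.48 log units; beyond the scatter)), so a larger acyclic amine here need not give a weaker inhibitor. The gap to piperidin-1-yl also widens (a 9.7-fold lower number from compound 2 to compound 4 (0.99 log units; beyond the scatter)), leaving that cyclic amine with the highest number of the three compounds on this shared core. No evidence at hand accounts for this order. On these data alone, whether the number keeps falling with dipropylamino stays open, as does whether morpholin-4-yl would track piperidin-1-yl.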